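Dimethylamino for Phenoxy: Compound 3 Ahead of Measurement

The compounds below may be only part of what the source reports. "The series", "measured", "known", "first", "only" and "open" are said of these compounds alone.

Two compounds carry numbers in a functional assay on M14 cells (Homo sapiens) for cytotoxicity, read by sulforhodamine B assay, with a stated time of 48 h, tested at 100 nM; a lower number here means a stronger effect, a higher number a weaker effect of the compound at the concentration tested. Among the measured compounds shown here, compound 1 `COc1cc(C)cc(-c2c(-c3ccnc(-c4ccc(C(C)=O)cc4)c3)cnn2CC#N)c1` gives 79%, and compound 2 `Cc1cc(O)cc(-c2nn(CC#N)cc2-c2ccnc(-c3ccc(Oc4ccccc4)cc3)c2)c1` gives 94%, the weaker effect of the two by a gap beyond the usual scatter, so compound 2 stands at the top of the numbers so far. Compound 3 `Cc1cc(O)cc(-c2nn(CC#N)cc2-c2ccnc(-c3ccc(N(C)C)cc3)c2)c1` keeps the core of compound 2 and differs in one place: dimethylamino in place of phenoxy on an aromatic carbon. For the measured compounds named here, no pair of measured compounds covers this change, so its size is open. The step of a number 6 percentage points lower from compound 2 to compound 3 (within the scatter) is expected to be small, toward a slightly stronger effect but not clearly beyond the scatter. Compound 3 is therefore estimated at 88%, within 70% to 100%.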

Compound 3, a percentage reported as activity, at one concentration (the size of the read-out at that concentration, not a potency): 82%
Compound 3: middle estimate off by 6 percentage points, on the high side, within the range that was stated.
By their numbers in this assay, from the lowest: compounds 1 and 3 (each within the scatter of the next); then compound 2.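

In this assay, among the compounds shown here, dimethylamino in place of phenoxy on an aromatic carbon gives a number 12 percentage points lower from compound 2 to compound 3 (beyond the scatter) and is the first change in one place that can be read. This aromatic carbon therefore responds to its group at the concentration tested, although only modestly for this exchange. No measurement shown accounts for the step.

Still open, as far as these compounds go, is how a primary amine, a carboxylic acid or a longer chain on this carbon would read. A single pair also leaves open whether the step comes from losing the ring or from bringing in the nitrogen.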